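Swapping amino for fluoro on the pyridine ether series

The source may hold more compounds than are shown below. What is called first, only, known or untested is meant among the compounds shown, and "the series" means these compounds.

Among the compounds with values here, compound 3 `CN1CCC[C@H]1COc1cncc(N)c1` gives 0.63 nM in an assay on membranes from brain for displacement of a labelled ligand from Neuronal acetylcholine receptor; alpha4/beta2 (Rattus norvegicus) (on this read-out lower numbers stand for stronger inhibition and higher numbers for weaker inhibition), the highest of the three numbers so far. Its nearest neighbour is compound 2 `CCCCCCc1cncc(OC[C@@H]2CCCN2C)c1`, which in this assay gives 0.32 nM; the step of a 2.0-fold higher number from compound 2 to compound 3 (0.29 log units; within the scatter). Compound 1 `CC(C)Cc1cncc(OC[C@@H]2CCCN2C)c1` gives 0.21 nM in this assay, and the step of a 3.0-fold higher number from compound 1 to compound 3 (0.48 log units; beyond the scatter). Between the two alkyl analogues the step of a 1.5-fold higher number from compound 1 to compound 2 (0.18 log units; within the scatter).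

Compound 4 `CN1CCC[C@H]1COc1cncc(F)c1` carries fluoro in place of amino on an aromatic carbon. Within the data shown here, no measured step exchanges an amino for a fluoro, so nothing bears on it directly. The two steps that end at compound 3 change the group at the same aromatic carbon, and both stayed small: the step of a 3.0-fold higher number from compound 1 to compound 3 (0.48 log units; beyond the scatter) was modest and the step of a 2.0-fold higher number from compound 2 to compound 3 (0.29 log units; within the scatter) lay within the scatter. On that basis the step of a 2.4-fold higher number from compound 3 to compound 4 (0.38 log units; beyond the scatter) is expected to be no more than modest, with its direction uncertain. Compound 4 is therefore estimated to give 1.5 nM in this assay, within a range from 0.4 nM to 6 nM.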

Compound 4, inhibition constant: 0.69 nM
For compound 4 the middle estimate is 2.2-fold (0.34 log units) above the measured one; the range from low to high includes it.
By their numbers in this assay, from the lowest: compounds 1, 2, 3 and 4 (each within the scatter of the next, the first and the last beyond it).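

At this aromatic carbon, the exchange of amino, with its hydrogen-bond donor and acceptor, for fluoro, with neither, leaves the binding number in this assay within the scatter (a 1.1-fold higher number from compound 3 to compound 4 (0.04 log units; within the scatter)), so the donor and acceptor counted on amino are not required for a sub-nanomolar-range value here. Replacing the alkyl groups with fluoro gives modest steps, both for hexyl (a 2.2-fold higher number from compound 2 to compound 4 (0.33 log units; beyond the scatter)) and for isobutyl (a 3.3-fold higher number from compound 1 to compound 4 (0.52 log units; beyond the scatter)), so among these four compounds, groups from a single heavy atom up to a hexyl chain shift the number only modestly. No measurement offered here explains why this carbon tolerates such different groups.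

On these data alone, whether that tolerance extends to a carboxylic acid, an amide or a phenyl ring at this carbon remains open. The compounds shown also leave open how a hydroxyl or methoxy group would compare with amino and fluoro.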